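The source may hold more compounds than are shown below. What is called first, only, known or untested is meant among the compounds shown, and "the series" means these compounds.

Measured compounds: compound 1 `O=c1ccoc2cc(OCc3cn(Cc4ccccc4Cl)nn3)ccc12` with 15100 nM in a functional assay on MDA-MB-231 cells (Homo sapiens) for cytotoxicity, read by MTT assay, with a stated time of 48 h; on this read-out higher numbers stand for weaker inhibition and lower numbers for stronger inhibition; compound 2 `O=c1ccoc2cc(OCc3cn(Cc4ccc([N+](=O)[O-])cc4)nn3)ccc12` with 71300 nM.

For the measured compounds named here, compound 2 holds the higher of the two numbers; the only step recorded is a 4.7-fold higher number from compound 1 to compound 2 (0.67 log units; beyond the scatter). Compound 3 `COc1ccc(Cn2cc(COc3ccc4c(=O)ccoc4c3)nn2)cc1` differs from compound 2 by methoxy in place of nitro on an aromatic carbon. Going by the values given here, no measured step swaps one group on that same aromatic carbon, so the step to compound 3 has no direct precedent; the step from compound 1 to compound 2 only shows that a change in this part of the molecule can move the number beyond the scatter. An expected step for compound 3 is therefore set as a 2.0-fold lower number from compound 2 to compound 3 (0.31 log units; beyond the scatter), a moderate decrease. Compound 3 is estimated at 35000 nM, with a range from 10000 nM to 110000 nM.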

Compound 3, half-maximal inhibitory concentration: > 100000 nM
Compound 3: a limit, no number; the forecaster's own chance of this, stated with the estimate: 15%; middle value at least 2.8-fold (0.45 log units) away from the limit.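

In this assay compound 3 gives only a limit of the assay, > 100000 nM. Methoxy in place of nitro on this aromatic carbon brings no lower number: the reading is an at least 1.4-fold higher number from compound 2 to compound 3 (0.14 log units; that floor lies within the scatter), and the 4-methoxyphenyl group also stands against the 2-chlorophenyl group, with an at least 6.6-fold higher number from compound 1 to compound 3 (0.82 log units; beyond the scatter), leaving compound 1 with the lowest number of the three. The floors of both steps rest on a limit rather than on a measured number: the limit of > 100000 nM in this assay, at which 1 of the 3 values shown sits.

On these data alone, the full size of the step from nitro to methoxy stays unknown. As far as these compounds go, whether an amine or a carboxylic acid on this aromatic carbon would give a lower number remains open.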